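The source may hold more compounds than are shown below. What is called first, only, known or untested is meant among the compounds shown, and "the series" means these compounds.

In a functional assay on MDA-MB-231 cells (Homo sapiens) for cytotoxicity, read by MTT assay, with a stated time of 72 h (on this read-out higher numbers stand for weaker inhibition and lower numbers for stronger inhibition), compound 3 `Cc1cccc(Cl)c1NC(=O)CN1CCN(c2nnc(Cc3ccccc3)c3ccccc23)CC1` gives 3920 nM and shares the low end of the numbers with compound 1 `O=C(CN1CCN(c2nnc(Cc3ccccc3)c3ccccc23)CC1)Nc1c(F)cccc1F` at 5490 nM as the two lie within the scatter of each other. Compound 2 `Cc1ccc(F)cc1NC(=O)CN1CCN(c2nnc(Cc3ccccc3)c3ccccc23)CC1` at 19200 nM stands clearly apart from both. Compound 4 `O=C(CN1CCN(c2nnc(Cc3ccccc3)c3ccccc23)CC1)Nc1ccc(F)c(Cl)c1` has not yet been measured. Its difference from compound 3 is 3-chloro-4-fluorophenyl in place of 2-chloro-6-methylphenyl on an amide-type nitrogen and it puts 3-chloro-4-fluorophenyl in place of 2-chloro-6-methylphenyl on an amide-type nitrogen.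

All three measured steps change the group at this same place. The step of a 1.4-fold lower number from compound 1 to compound 3 (0.15 log units; within the scatter) stays within the scatter, while a 3.5-fold higher number from compound 1 to compound 2 (0.54 log units; beyond the scatter) and a 4.9-fold lower number from compound 2 to compound 3 (0.69 log units; beyond the scatter) go beyond it and remain modest. None of these steps involves the entering group, so they suggest a likely size more firmly than a direction. With compound 3 at 3920 nM at the low end of that span, a change at this place has more room to raise the number than to lower it. The expected change is a modest one of a 2.0-fold higher number from compound 3 to compound 4 (0.31 log units; beyond the scatter) in this assay on this estimate. For compound 4 the value is estimated at 8000 nM with 3000 nM to 20000 nM as its expected range.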

Compound 4, half-maximal inhibitory concentration: 7360 nM
Compound 4: middle estimate off by 1.1-fold (0.04 log units), on the high side, within the range that was stated.
By their numbers in this assay, from the lowest: compounds 3, 1 and 4 (each within the scatter of the next); then compound 2.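

In this assay, 3-chloro-4-fluorophenyl on the amide-type nitrogen gives a 1.9-fold higher number from compound 3 to compound 4 (0.27 log units; within the scatter) and a 1.3-fold higher number from compound 1 to compound 4 (0.13 log units; within the scatter), so this third group joins 2-chloro-6-methylphenyl and 2,6-difluorophenyl in one band, with all three pairs within the scatter. Against 5-fluoro-2-methylphenyl, the same group gives a 2.6-fold lower number from compound 2 to compound 4 (0.42 log units; beyond the scatter), so compound 2 is now set apart from each of the other three compounds, and the earlier gaps from compound 2 no longer rest on only two groups. At this place, then, the four aryl groups shown form a single band and one outlier, and the band holds a group that has no methyl and no fluorine in common with 2-chloro-6-methylphenyl and 2,6-difluorophenyl respectively in any consistent way, so no single substituent marks membership.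

On these data alone, all four compounds carry a halogen on this ring, so it remains open how a ring bearing an amine or a carboxylic acid, or a longer chain on the amide-type nitrogen, would read in this assay. Nothing given here explains why compound 2 stands apart from the rest.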